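Amine replacement on the core of compound 1

This account rests on a few compounds, and the source may have more. Where it says the series, first, only, none or still open, it means among the compounds named here.

Measured compounds:
compound 1 `CCCCN(C)Cc1c(C(F)(F)F)nc2n(-c3c(C)cc(C)cc3C)c(Cl)cn12` — 310 nM
compound 2 `CCCCN(Cc1ccccc1)Cc1c(C(F)(F)F)nc2n(-c3c(C)cc(C)cc3C)c(Cl)cn12` — 130 nM

Among the measured compounds shown here, compound 1 stands highest of the two numbers so far in an assay on cells for displacement of a labelled ligand from corticotropin-releasing factor receptor 1 (Homo sapiens), with a stated time of 100 min; on this read-out higher numbers stand for weaker inhibition and lower numbers for stronger inhibition; the only neighbour, compound 2, sits lower, and the step of a 2.4-fold lower number from compound 1 to compound 2 (0.38 log units; beyond the scatter) is the single change measured in the set. That step brought in a phenyl group on the amine side chain.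

The next compound, compound 3 `Cc1cc(C)c(-n2c(Cl)cn3c(CN4CCCC4c4ccccc4)c(C(F)(F)F)nc23)c(C)c1`, differs from compound 1 as follows: 2-phenylpyrrolidin-1-yl in place of butyl(methyl)amino on a saturated chain carbon bound to an aromatic carbon. The change again brings in a phenyl group, now carried within a ring at the amine nitrogen, while the butyl chain and methyl group are lost. For the measured compounds named here, only the step from compound 1 to compound 2 bears on this, and it was modest but beyond the scatter, in the lowering direction. Going by the values given here, a lowering of similar size is therefore expected for compound 3, with no measured step on ring closure to sharpen it. The expected step is a 2.1-fold lower number from compound 1 to compound 3 (0.32 log units; beyond the scatter). In this assay compound 3 is expected at 150 nM, within the range 50 nM to 500 nM.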

Compound 3, inhibition constant: > 7000 nM
Compound 3: a limit, no number; the forecaster's own chance of this, stated with the estimate: 3%; at least 46-fold (1.66 log units) between middle value and limit.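

The entry for compound 3 is a limit of the assay and not a number: the limit of > 7000 nM in this assay, at which 1 of the 3 values shown sits. In this assay, the change to 2-phenylpyrrolidin-1-yl on the saturated chain carbon bound to an aromatic carbon gives an at least 22-fold higher number from compound 1 to compound 3 (1.35 log units; beyond the scatter), opposite in direction to a 2.4-fold lower number from compound 1 to compound 2 (0.38 log units; beyond the scatter). A phenyl group in the amine portion therefore does not by itself go with a lower number at this position: compound 2 keeps the butyl chain and carries its phenyl group on an open chain, whereas compound 3 has lost the butyl chain and holds its phenyl group on a five-membered ring.

The compounds shown do not separate the ring closure, the phenyl group on that ring and the loss of the butyl chain as sources of the step, as all three changes arrive together in compound 3. Plain pyrrolidin-1-yl without the phenyl group, or an open-chain amine such as butyl(2-phenylethyl)amino, would bear on that question, and the size of the step beyond the limit also remains unknown.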